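A few compounds are considered here, and "the series" means these few. Any claim that something is new, unique, unknown or untested is made for them only; others in the source may bear on it.

Working notes on the series. In an assay on SH-SY5Y cells for inhibition of Voltage-dependent N-type calcium channel subunit alpha-1B (Homo sapiens), read by FLIPR and calcium flux, with stated times of 600 s and 300 s, in the presence of a further agent that is not named here (on this read-out lower numbers stand for stronger inhibition and higher numbers for weaker inhibition), compound 1 `CN(Cc1ccc(OCCCNC(=N)N)cc1)c1nc2ccc(Oc3ccc(C(F)(F)F)cc3)cc2s1` gives 185000 nM. Compound 2 `CN(Cc1ccc(OCCCN)cc1)c1nc2ccc(Oc3ccccc3)cc2s1` gives 49000 nM in this assay. Compound 3 `NCCCOc1ccc(CNc2nc3ccc(Oc4ccc(C(F)(F)F)cc4)cc3s2)cc1` gives 59000 nM in this assay, the second highest of the three numbers; its gap to compound 2 lies within the scatter, while its gap to compound 1 lies beyond the scatter. Compound 4 `CN(Cc1ccc(OCCCN)cc1)c1nc2ccc(Oc3ccc(C(F)(F)F)cc3)cc2s1` has not yet been measured.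

Compound 4 differs from compound 3 in one place: methyl in place of hydrogen on a nitrogen on an aromatic ring. Among the compounds with values here, no pair of measured compounds covers this change by itself. Compound 2 already carries the methyl on that nitrogen and gives 49000 nM, a number within the scatter of that of compound 3, although compound 2 also lacks the trifluoromethyl group on the phenoxy ring. On this basis the change is expected to move the number little, with no step beyond the scatter. Compound 4 is estimated at 50000 nM in this assay, with a range from 20000 nM to 130000 nM. The expected step, a 1.2-fold lower number from compound 3 to compound 4 (0.07 log units; within the scatter), is small.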

Compound 4, half-maximal inhibitory concentration: 283000 nM
For compound 4 the middle estimate is 5.7-fold (0.75 log units) below the measured one; the whole stated range lies below it.
By their numbers in this assay, from the lowest: compounds 2 and 3 (each within the scatter of the next); then compounds 1 and 4 (each within the scatter of the next).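

In this assay methyl in place of hydrogen on a nitrogen on an aromatic ring gives a 4.8-fold higher number from compound 3 to compound 4 (0.68 log units; beyond the scatter) and so shows that this position responds to this change, at least with trifluoromethyl on the phenoxy ring. With the methyl in place, trifluoromethyl in place of hydrogen on an aromatic carbon gives a 5.8-fold higher number from compound 2 to compound 4 (0.76 log units; beyond the scatter) and is therefore also tied to a step beyond the scatter. Within the data shown here, a hydrogen atom in place of a group of 3 heavy atoms on an amine nitrogen gives a 1.5-fold higher number from compound 1 to compound 4 (0.18 log units; within the scatter) and shows no separable step in this setting.

On these data alone, whether the methyl step holds without the trifluoromethyl group stays open, as does the outcome with an ethyl group on that nitrogen or a carboxylic acid in place of the amine. No measurement shown here accounts for these steps.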